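The source may report more compounds than this note shows. Statements on the series, on what has been measured and on what is new or still open speak of the compounds shown alone.

Compound 2, `N#C/C(=C\c1c[nH]c2cc(F)ccc12)C(=O)c1c[nH]c2cc(F)ccc12`, gives > 50000 nM in a functional assay on PC-3 cells (Homo sapiens) for cytotoxicity, read by WST assay, with a stated time of 48 h (on this read-out lower numbers stand for stronger inhibition and higher numbers for weaker inhibition), and this is a limit of the assay, not a number. Compound 3, `COc1ccc2[nH]cc(C(=O)/C(C#N)=C/c3c[nH]c4cc(F)ccc34)c2c1`, which also carries a methoxy, gives > 50000 nM, likewise a limit. Going by the values given here, compound 1, `COc1ccc2c(/C=C(\C#N)C(=O)c3c[nH]c4cc(F)ccc34)c[nH]c2c1`, is the only compound with a numerical reading in this assay, at 21400 nM.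

The next change leads to compound 4, `COc1ccc2c(C(=O)/C(C#N)=C/c3c[nH]c4cc(F)ccc34)c[nH]c2c1`, and is counted as methoxy in place of fluoro on an aromatic carbon. It places methoxy in place of fluoro on an aromatic carbon. Among the compounds with values here, the one measured step that bears on it is an at least 2.3-fold higher number from compound 1 to compound 2 (0.36 log units; beyond the scatter). That step runs the opposite way and falls on a different aromatic carbon, so it transfers only loosely. Read in reverse, it suggests a modest move to a lower number in this assay, while compound 3 at > 50000 nM shows that a methoxy does not guarantee this. A modest gain at most is therefore expected, and compound 4 may well stay at the limit.

The expected step is an at least 1.6-fold lower number from compound 2 to compound 4 (0.22 log units; that floor lies within the scatter). Compound 4 is estimated at 30000 nM, with an expected range of 12000 nM to 50000 nM.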

Compound 4, half-maximal inhibitory concentration: 22500 nM
For compound 4 the middle estimate is 1.3-fold (0.12 log units) above the measured one; measured number inside the range.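

In this assay, methoxy in place of fluoro on this aromatic carbon gives an at least 2.2-fold lower number from compound 2 to compound 4 (0.34 log units; beyond the scatter), the first step measured at this carbon, and it lifts the series off the assay limit. The earlier step fell on a different aromatic carbon, so this result adds direct support for methoxy at this position. Compound 3, whose methoxy sits on another aromatic carbon, gives > 50000 nM, which is a limit of the assay, so carrying a methoxy is not enough and its place on the core matters among these compounds.

From the compounds shown here alone, the full size of the step remains unknown because the starting value is not a number: the limit of > 50000 nM in this assay, at which 2 of the 4 values shown sit. Going by these compounds, whether an amine, a hydroxy or a longer ether chain such as ethoxy on this carbon would give a lower number than methoxy remains open.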